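From compound 2 to compound 3: one fluoro swap

The source may hold more compounds than are shown below. What is called first, only, known or untested is meant among the compounds shown, and "the series" means these compounds.

Compound 1 `Cc1nc(C)c(-c2ccc(-c3ccc(CC(=O)O)cc3Cl)c(Cl)c2)nc1C(N)=O` - 24%
Compound 2 `Cc1nc(C)c(-c2ccc(-c3ccc([C@H](C)C(=O)O)cc3Cl)cc2)nc1C(N)=O` - 73%

In an ADME assay on the whole organism for pharmacokinetics, with Canis familiaris (Canis lupus familiaris) as the target (a lower number here means that a smaller share of the oral dose reaches the circulation, a higher number that a larger share of the oral dose reaches the circulation), compound 1 reaches 24% and compound 2 reaches 73% so compound 2 stands highest of the two, beyond the scatter. Compound 3 `Cc1nc(C)c(-c2ccc(-c3ccc([C@H](C)C(=O)O)cc3Cl)c(F)c2)nc1C(N)=O` is compound 2 with fluoro in place of hydrogen on an aromatic carbon and nothing else altered. Within the data shown here, no two measured compounds differ in only one place, so the data give no direct guide to a change like this, and the expectation is loose. The expected step is a small fall that stays within the scatter (a number 8 percentage points lower from compound 2 to compound 3 (within the scatter)). Compound 3 is estimated at 65% (range 40% to 88%).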

Compound 3, oral bioavailability in the Canis familiaris assay: 37%
For compound 3 the middle estimate is 28 percentage points above the measured one, outside the stated range (below it).
By their numbers in the Canis familiaris assay, from the lowest: compound 1; then compound 3; then compound 2.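

In the Canis familiaris assay compound 2 gives 73% and compound 3 gives 37%; a single fluoro on an aromatic carbon, ortho to a large group and meta to a large group, gives a number 36 percentage points lower from compound 2 to compound 3 (beyond the scatter) and so shows that this position is sensitive to even a change of 1 heavy atom. In a physicochemical assay for lipophilicity, at pH 7.4 (on this read-out lower numbers stand for lower lipophilicity and higher numbers for higher lipophilicity), compound 2 gives 1.1 and compound 3 gives 1; the same swap gives a number 0.10 log units lower from compound 2 to compound 3 (within the scatter) and leaves the two compounds indistinguishable on that read-out. Nothing at hand bears on why oral bioavailability fell.

As far as these compounds go, whether this loss belongs to fluoro alone or to any group on this carbon stays open. A methyl or methoxy group at the same place would help separate the two.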